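This account rests on a few compounds, and the source may have more. Where it says the series, first, only, none or still open, it means among the compounds named here.

Measured so far:
compound 1 `CCC(C)(C)Cc1c[nH]c(CCc2ccc(-c3cccc(C)n3)cc2)n1`: 105 nM
compound 2 `CCC(C)(C)Cc1c[nH]c(CCc2ccc(-c3cccc(C#N)n3)cc2)n1`: 193 nM

In a functional assay on HEK293 cells for agonist activity at Bombesin receptor subtype-3 (Homo sapiens), read by luminescence and calcium flux, with a stated time of 10 min (a lower number here means that less compound is needed, a higher number that more compound is needed for the effect), compound 2 gives 193 nM, the highest of the two numbers; the nearest is compound 1, and the step of a 1.8-fold higher number from compound 1 to compound 2 (0.26 log units; within the scatter) is the only measured one.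

Compound 3 `CCC(C)(C)Cc1c[nH]c(CCc2ccc(-c3cccnc3)cc2)n1` is unmeasured. It differs from compound 2 by pyridin-3-yl in place of 6-cyanopyridin-2-yl on an aromatic carbon. For the measured compounds named here, the cyano group that leaves is the one introduced in a 1.8-fold higher number from compound 1 to compound 2 (0.26 log units; within the scatter); the shift of the ring nitrogen has no measured counterpart. The expected step for compound 3 is therefore small, a 1.5-fold lower number from compound 2 to compound 3 (0.17 log units; within the scatter), nothing beyond the scatter. Compound 3 is estimated at 130 nM, range 50 nM to 400 nM.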

Compound 3, half-maximal effective concentration: 131 nM
Estimate against measurement, compound 3: 1.0-fold (0.00 log units) below; the range from low to high includes it.
By their numbers in this assay, from the lowest: compounds 1, 3 and 2 (each within the scatter of the next).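

At this place on the aromatic carbon, para to a large group, pyridin-3-yl replaces 6-cyanopyridin-2-yl with a 1.5-fold lower number from compound 2 to compound 3 (0.17 log units; within the scatter) and replaces 6-methylpyridin-2-yl with a 1.2-fold higher number from compound 1 to compound 3 (0.10 log units; within the scatter) in this assay. A pyridine ring carrying neither nitrile nor methyl and with its nitrogen moved therefore stays within the scatter of both substituted compounds. No measured evidence bears on this result.

These compounds do not separate the loss of the substituent from the shift of the ring nitrogen. Going by these compounds, whether a phenyl ring, or a pyridine carrying an amine or a carboxylic acid, would give a step beyond the scatter remains open.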